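Methoxy for Chloro on the Benzyl Ring of Compound 3

The source may hold more compounds than are shown below. What is called first, only, known or untested is meant among the compounds shown, and "the series" means these compounds.

The measured compounds, from one series with a shared core:
compound 1, `O=S(=O)(NCCCNCc1cccc(Cl)c1)c1cc(C(F)(F)F)cc(C(F)(F)F)c1`, 12000 nM;
compound 2, `O=S(=O)(NCCCNCc1ccc(C(F)(F)F)cc1)c1cc(C(F)(F)F)cc(C(F)(F)F)c1`, 3200 nM;
compound 3, `O=S(=O)(NCCCNCc1ccccc1Cl)c1cc(C(F)(F)F)cc(C(F)(F)F)c1`, 15000 nM.

In a functional assay on PANC-1 cells (Homo sapiens) for inhibition, read by MTT assay, with a stated time of 72 h (on this read-out higher numbers stand for weaker inhibition of growth and lower numbers for stronger inhibition of growth), compound 3 gives the highest of the three numbers. Its step from compound 1 is small, a 1.3-fold higher number from compound 1 to compound 3 (0.10 log units; within the scatter), so the two cannot be ordered against each other, while against compound 2 the gap is clearer, a 4.7-fold higher number from compound 2 to compound 3 (0.67 log units; beyond the scatter). Going by the values given here, the one step that separates clearly, a 3.8-fold lower number from compound 1 to compound 2 (0.57 log units; beyond the scatter), shows that the group on the benzyl ring can move the number by a modest amount.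

Compound 4, `COc1ccccc1CNCCCNS(=O)(=O)c1cc(C(F)(F)F)cc(C(F)(F)F)c1`, differs from compound 3 in one place: methoxy in place of chloro on an aromatic carbon. Among the compounds with values here, no measured step swaps chloro for methoxy, so the change has no direct precedent here. The steps that do exist on this ring are either within the scatter or modest, and a similar scale is the most that can be assumed.

Compound 4 is therefore expected to stay close to compound 3, with a step of a 1.3-fold lower number from compound 3 to compound 4 (0.10 log units; within the scatter) that may not exceed the scatter. The estimated value of compound 4 in this assay is 12000 nM, in a range from 5000 nM to 30000 nM.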

Compound 4, concentration for 50% growth inhibition: 12000 nM
Compound 4: the middle estimate sits on the measured number at the digits printed; the range from low to high includes it.
By their numbers in this assay, from the lowest: compound 2; then compounds 1, 4 and 3 (each within the scatter of the next).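

In this assay methoxy and chloro at this aromatic carbon, ortho to a large group, cannot be told apart: the change gives a 1.3-fold lower number from compound 3 to compound 4 (0.10 log units; within the scatter) even though methoxy, unlike chloro, counts a hydrogen-bond acceptor. Compound 4 also cannot be separated from the compound carrying 3-chlorophenyl, with no change at the digits printed from compound 1 to compound 4 (within the scatter) on that step, whereas the compound carrying 4-(trifluoromethyl)phenyl remains apart, with a 3.8-fold higher number from compound 2 to compound 4 (0.57 log units; beyond the scatter) as the step, so among these four compounds every step beyond the scatter still involves compound 2. Nothing available here offers an explanation for why the 2-methoxyphenyl and 2-chlorophenyl compounds read alike in this growth assay.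

The compounds shown leave open whether a hydroxyl, an amine or a nitrile at this same aromatic carbon would also fall within the scatter of chloro and methoxy, or would instead move the number as far as the step to compound 2 does. They also leave open whether a longer chain in place of the one shared by all four compounds would keep these benzyl groups as close together, or would change the gap that sets compound 2 apart.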